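A few compounds are considered here, and "the series" means these few. Any claim that something is new, unique, unknown or untested is made for them only; others in the source may bear on it.

Measured so far:
compound 1, `C[S+]([O-])C[C@H]1O[C@@H](n2cnc3c(N)nc(F)nc32)[C@H](O)[C@@H]1O`, 13000 nM 
compound 2, `C[S+]([O-])C[C@H]1O[C@@H](n2cnc3c(N)nc(Cl)nc32)[C@H](O)[C@@H]1O`, 259000 nM 
compound 3, `CC(=O)NC[C@H]1O[C@@H](n2cnc3c(N)nc(F)nc32)[C@H](OC(C)=O)[C@@H]1OC(C)=O`, 138000 nM 

These numbers come from an ADME assay on L6 cells (Rattus norvegicus) for inhibition, read by resazurin assay, with a stated time of 72 h; a higher number here means a weaker inhibitor, a lower number a stronger inhibitor. Compound 1 and compound 2 share a core and differ in one place: chloro in place of fluoro on an aromatic carbon. That change made a step of a 20-fold higher number from compound 1 to compound 2 (1.30 log units; beyond the scatter). Compound 4, `CC(=O)NC[C@H]1O[C@@H](n2cnc3c(N)nc(Cl)nc32)[C@H](OC(C)=O)[C@@H]1OC(C)=O`, has not yet been measured in this assay; it differs from compound 3 by the same change in the same surroundings, (chloro in place of fluoro on an aromatic carbon). The difference between the core of compound 1 and the core of compound 3 is not broken down here; in this assay compound 3 stands far from compound 1 and close to compound 2. Because the earlier step was a 20-fold higher number from compound 1 to compound 2 (1.30 log units; beyond the scatter), the same change is expected to give an 11-fold higher number from compound 3 to compound 4 (1.04 log units; beyond the scatter), though the cores differ, so the size is less certain. Compound 4 is estimated at 1500000 nM, with a likely range from 300000 nM to 5000000 nM.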

Compound 4, half-maximal inhibitory concentration: 190000 nM
Estimate against measurement, compound 4: 7.9-fold (0.90 log units) above, and the stated range ends above it.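

In this assay, putting chloro in place of fluoro gave a 1.4-fold higher number from compound 3 to compound 4 (0.14 log units; within the scatter), so the large step seen on the core of compound 1 did not carry over to the core of compound 3. The two steps differ by more than the scatter allows: the same change on two cores in this assay, a 20-fold higher number (1.30 log units; beyond the scatter) from compound 1 to compound 2 and a 1.4-fold higher number (0.14 log units; within the scatter) from compound 3 to compound 4, 14-fold (1.16 log units) apart, beyond the scatter of two such steps. This shows that the size of this change depends on the core it sits on, but it does not show which part of the difference between the two cores matters, and two pairs set no general rule.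

The compounds shown leave open which single difference between the cores decides the size of the step. They also leave open how a bromo group or an amine would behave on the same aromatic carbon.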